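Trifluoromethyl in place of fluoro: the next step

The source may hold more compounds than are shown below. What is called first, only, known or untested is meant among the compounds shown, and "the series" means these compounds.

For the measured compounds named here, in a functional assay on KB 3-1 cells (Homo sapiens) for cytotoxicity, read by MTT assay, with a stated time of 68 h (a higher number here means a weaker inhibitor, a lower number a stronger inhibitor), compound 3 `O=C(Nc1cccc(-c2ccc(F)cc2)c1)C(Cl)Cl` gives 26200 nM, the only actual number among the measured compounds. Compound 1 `O=C(Nc1cccc(-c2ccc(-c3ccccc3)cc2)c1)C(Cl)Cl` shows > 50000 nM, which is a limit of the assay. Compound 2 `Cc1ccc(-c2cccc(NC(=O)C(Cl)Cl)c2)cc1` shows > 50000 nM, also a limit. Compound 4 `O=C(Nc1cccc(-c2ccc(C(F)(F)F)cc2)c1)C(Cl)Cl` carries trifluoromethyl in place of fluoro on an aromatic carbon, para to a large group: trifluoromethyl in place of fluoro on an aromatic carbon. Going by the values given here, two measured steps bear on this change, an at least 1.9-fold lower number from compound 1 to compound 3 (0.28 log units; that floor lies within the scatter) and an at least 1.9-fold lower number from compound 2 to compound 3 (0.28 log units; that floor lies within the scatter), and both floors lie within the scatter, so they offer only weak guidance. The expected result is a 1.3-fold higher number from compound 3 to compound 4 (0.13 log units; within the scatter), with no change beyond the scatter anticipated, although a limit reading remains possible. For compound 4 the estimated value is 35000 nM, with an expected range of 15000 nM to 70000 nM.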

Compound 4, half-maximal inhibitory concentration: > 50000 nM
Compound 4: a limit, no number; the forecaster's own chance of this, stated with the estimate: 45%; middle value at least 1.4-fold (0.15 log units) from the limit.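

Trifluoromethyl in place of fluoro gives an at least 1.9-fold higher number from compound 3 to compound 4 (0.28 log units; that floor lies within the scatter), so no change beyond the scatter is established at this position. In this assay compound 4 gives > 50000 nM, which is a limit and not a number. Fluoro thus remains the only group here with a readable value, and the steps from compound 1 and compound 2 to compound 4 cannot be read: the limit of > 50000 nM in this assay, at which 3 of the 4 values shown sit.

From the compounds shown here alone, the true values behind these limits stay open. So does whether chloro, an amine or a carboxylic acid at this position would give a number in this series.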